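Double-bond geometry: from compound 2 to compound 3

A few compounds are considered here, and "the series" means these few. Any claim that something is new, unique, unknown or untested is made for them only; others in the source may bear on it.

Compound 1 `CCCCCCCC/C=C\c1c(C)nc(C)c(/C=C\CCCCCCCC)c1C` reaches only a limit in a functional assay on M12 cells (Homo sapiens) for antiproliferative activity, read by WST assay, with a stated time of 72 h (on this read-out lower numbers stand for an effect already at smaller amounts and higher numbers for an effect only at larger amounts of compound), > 30 uM. Among the measured compounds shown here, compound 2 `CCCCCCCC/C=C\c1c(C)c(/C=C\CCCCCCCC)c2[n+](c1C)CCC2` gives 3.3 uM in this assay, the only true number so far. Compound 3 `CCCCCCCC/C=C/c1c(C)c(/C=C/CCCCCCCC)c2[n+](c1C)CCC2` keeps its atoms and bonds: the two compounds have the same atoms and bonds and differ only in configuration as drawn: 2 of 2 stereo elements differ; a double bond is drawn Z in compound 2 and E in compound 3; a double bond is drawn Z in compound 2 and E in compound 3. For the measured compounds named here, no measured pair shows what such a change does, so the expectation is weakly founded: little movement, close to the scatter, with a slight lean towards larger amounts. The expected change is a 1.2-fold higher number from compound 2 to compound 3 (0.08 log units; within the scatter). For compound 3 the estimate is 4 uM, with an expected range of 1.5 uM to 11 uM.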

Compound 3, concentration for half-maximal effect: 2.2 uM
The estimate for compound 3 lay 1.8-fold (0.26 log units) above the measured number; low and high end bracket the measured number.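

In this assay, among the compounds shown here, the first measured reading of double-bond geometry is a 1.5-fold lower number from compound 2 to compound 3 (0.18 log units; within the scatter) and so gives no ranking of compound 2 and compound 3. Drawing both chain double bonds E rather than Z therefore leaves the read-out within the usual scatter. Geometry at these two double bonds is, on this pair, not a lever on antiproliferative activity.

As far as these compounds go, both double bonds change together, so the contribution of each one stays open. Also open, from the compounds shown here alone, is what a saturated chain, a longer chain or a terminal carboxylic acid would do in their place.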